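This account rests on a few compounds, and the source may have more. Where it says the series, first, only, none or still open, it means among the compounds named here.

Values in a functional assay on MIA PaCa-2 cells (Homo sapiens) for antiproliferative activity, read by sulforhodamine B assay, with a stated time of 48 h; on this read-out higher numbers stand for weaker inhibition and lower numbers for stronger inhibition:
- compound 1 `COc1cc(OC)c2sc(-c3ccc(N/C=C\C(=O)c4ccc(OC)c(O)c4)c(C)c3)nc2c1`: 22100 nM
- compound 2 `COc1ccc(C(=O)/C=C\Nc2ccc(-c3nc4cc(OC)c(OC)c(OC)c4s3)cc2C)cc1O`: 15400 nM
- compound 3 `COc1ccc2nc(-c3ccc(N/C=C\C(=O)c4ccc(OC)c(O)c4)c(C)c3)sc2c1`: 17000 nM

In this assay, compound 1 at 22100 nM is not separated from compound 2 or compound 3; all three values lie within the scatter of one another.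

Compound 4 `COc1cc(OC)c2sc(-c3ccc(N/C=C\C(=O)c4ccc(OC)c([N+](=O)[O-])c4)c(C)c3)nc2c1` is compound 1 with nitro in place of hydroxy on an aromatic carbon, 3-hydroxy-4-methoxyphenyl becoming 4-methoxy-3-nitrophenyl: nitro in place of hydroxy on an aromatic carbon.

Among the compounds with values here, the one measured step, a 1.4-fold lower number from compound 1 to compound 2 (0.16 log units; within the scatter), is a different change, methoxy in place of hydrogen on an aromatic carbon. Within the data shown here, all three measured compounds carry 3-hydroxy-4-methoxyphenyl, so no measured step tests this exchange, and the data give no direction for it.

The expected step is a 1.1-fold lower number from compound 1 to compound 4 (0.04 log units; within the scatter), with nothing expected beyond the scatter, though the uncertainty is wide.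

Compound 4 is expected at 20000 nM, with an estimated range of 7000 nM to 60000 nM.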

Compound 4, half-maximal inhibitory concentration: 13900 nM
Beside the measured number, compound 4's estimate is 1.4-fold (0.16 log units) above it, and the stated range covers the measured number.
By their numbers in this assay, from the lowest: compounds 4, 2, 3 and 1 (each within the scatter of the next).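

In this assay, nitro in place of hydroxy on an aromatic carbon, ortho to a methoxy group, gives a 1.6-fold lower number from compound 1 to compound 4 (0.20 log units; within the scatter) and so leaves the value within the scatter. At this position, 4-methoxy-3-nitrophenyl therefore reads level with 3-hydroxy-4-methoxyphenyl on the core of compound 1, even though the hydrogen-bond donor of the hydroxy is gone. No measurement here bears on why the two groups read alike. From the compounds shown here alone, whether an amine or a carboxylic acid at this position would separate from the hydroxy stays open. Also open, going by these compounds, is whether nitro reads the same on the cores of compound 2 and compound 3.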